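The compounds below may be only part of what the source reports. "The series", "measured", "known", "first", "only" and "open" are said of these compounds alone.

Measured so far in a functional assay on RXF 393 cells (Homo sapiens) for inhibition; a higher number here means a weaker inhibitor of growth, a lower number a stronger inhibitor of growth:

- compound 1, `CC(=O)CC/C=C(\C)CCC1=C(C)CCCC1(C)C`: gives > 15000 nM, which is a limit of the assay.
- compound 2, `C=C1CCC[C@H]2[C@](C)(CC[C@]3(C)CC[C@@H]([C@@H](C)C(=O)O)OO3)[C@@H](C)CC[C@]12C`: gives 2950 nM.
- compound 3, `C=C1CCCC(C)(C)C1(O)CC/C(C)=C/CC[C@]1(C)CC[C@@H]([C@@H](C)C(=O)OC)OO1`: gives > 17500 nM, again a limit of the assay.

For the measured compounds named here, compound 2 is therefore the only member of the series with a numerical result in this assay; the other two values are limits and not numbers, as noted for compound 1 the limit of > 15000 nM in this assay, at which 1 of the 3 values shown sits, and for compound 3 (the limit of > 17500 nM in this assay, at which 1 of the 3 values shown sits). Going by the values given here, no pair of measured compounds differs in a single place, so no measured step can be read off.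

Compound 4, `C=C1CCC[C@H]2[C@](C)(CC[C@]3(C)CC[C@H]([C@@H](C)C(=O)O)OO3)[C@@H](C)CC[C@]12C`, is the next compound to go into this assay. It is related to compound 2 as follows: the two compounds have the same atoms and bonds and differ only in configuration as drawn: 1 of 7 stereo elements differ; a stereocentre at a saturated ring carbon is drawn S in compound 2 and R in compound 4.

With no measured step of this kind in the series, the expectation for the step from compound 2 to compound 4 rests on the change alone: an inversion at one ring stereocentre is expected to cost little, giving a step of a 1.5-fold higher number from compound 2 to compound 4 (0.18 log units; within the scatter) of a size at or only slightly beyond the usual scatter, toward weaker inhibition. Compound 4 is accordingly estimated at 4500 nM, with a range from 1500 nM to 13000 nM.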

Compound 4, concentration for 50% growth inhibition: 1220 nM
The estimate for compound 4 lay 3.7-fold (0.57 log units) above the measured number; measured number outside the range, below it.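

In this assay, for the compounds shown here, inversion at this one saturated ring carbon is the first change that can be read as a step: a 2.4-fold lower number from compound 2 to compound 4 (0.38 log units; beyond the scatter). Within this pair, the R configuration as drawn at this stereocentre gives the stronger inhibitor, so the position is not indifferent to configuration, and the shift can be assigned to this stereocentre alone: the fact that compounds 2 and 4 differ only in the configuration as drawn The step is modest and rests on a single pair.

Going by these compounds alone, compound 3 gives > 17500 nM, a limit of the assay and not a number, and it forms no step with compound 2 or compound 4. As far as these compounds go, whether the preference for the R configuration holds with an amide or a primary amine in place of the carboxylic acid remains open, as does the effect of inverting any other stereocentre.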